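A few compounds are considered here, and "the series" means these few. Any claim that something is new, unique, unknown or untested is made for them only; others in the source may bear on it.

Working notes on the series in an assay on HEK293 cells for positive allosteric modulation of metabotropic glutamate receptor 5 (Homo sapiens), read by FLIPR, with a stated time of 1 h; a lower number here means that less compound is needed, a higher number that more compound is needed for the effect.

Compound 1 `Cc1cccc(C#Cc2nc3c(s2)C(=O)NCC3)c1` returns no number in this assay; the value recorded for compound 1 is a limit, > 10000 nM. Compound 3 `Fc1cccc(C#Cc2nc3c(s2)CN(C2CCOC2)CC3)c1` likewise returns only a limit in this assay, > 10000 nM. Within the data shown here, compound 2 `CN1CCc2nc(C#Cc3ccccc3)sc2C1` is the one member with a measured value: in this assay compound 2 gives 34 nM. Among the measured compounds shown here, compound 2 thus stands as the sole number in the set, while the other two sit at the limit of > 10000 nM in this assay, at which 2 of the 3 values shown sit, so no ranking among them is possible beyond noting that compound 2 alone is quantified.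

For the measured compounds named here, no two measured compounds differ in a single place, so no measured step is available to calibrate the change to compound 4 `O=S(=O)(C1CC1)N1CCc2nc(C#Cc3ccccc3)sc2C1`. Compound 4 differs from compound 2 as follows: cyclopropylsulfonyl in place of methyl on an amine nitrogen in a ring.

With nothing measured along this direction, the expectation for compound 4 rests on compound 2 alone, at 34 nM, as the starting point. The step expected in this assay is a 3.5-fold higher number from compound 2 to compound 4 (0.55 log units; beyond the scatter), a loss beyond the usual scatter but not reaching the limit. Compound 4 is accordingly estimated at 120 nM in this assay, with a range from 30 nM to 1500 nM.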

Compound 4, half-maximal effective concentration: > 10000 nM
Compound 4 was reported as a limit (the forecaster's own chance of this, stated with the estimate: 15%); middle value at least 83-fold (1.92 log units) from the limit.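

In this assay, among these compounds, cyclopropylsulfonyl in place of methyl on an amine nitrogen in a ring gives an at least 290-fold higher number from compound 2 to compound 4 (2.46 log units; beyond the scatter), the first change that can be read at a single place, and it is a large one. Compound 4 gives only a limit, not a number: > 10000 nM. The substituent on this nitrogen therefore matters strongly to the read-out, since compound 2 remains the only quantified member and compound 4 now joins the others at the limit: the limit of > 10000 nM in this assay, at which 3 of the 4 values shown sit.

The compounds shown leave open whether the sulfonyl link or the cyclopropyl ring accounts for the loss, as both enter together in compound 4, and how far the loss extends past the limit. A methylsulfonyl or an acetyl group on the same amine nitrogen would separate the link from the ring, while a cyclopropylmethyl group or the free secondary amine would show how much room the position allows around the methyl of compound 2.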